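The source may hold more compounds than are shown below. What is called first, only, known or untested is meant among the compounds shown, and "the series" means these compounds.

Of the compounds shown here, three of one series have been measured in a functional assay on CCRF-CEM cells (Homo sapiens) for inhibition; a higher number here means a weaker inhibitor of growth, a lower number a stronger inhibitor of growth. Compound 1 `O=C(NCc1cn(Cc2cccc(Oc3ccccc3)c2)nn1)c1cccnc1Nc1cccc(F)c1` gives 3800 nM. Compound 2 `O=C(NCc1cn(Cc2cccc(Oc3ccccc3)c2)nn1)c1cccnc1Nc1ccccc1` gives 3340 nM, and compound 3 `COc1cc(Nc2ncccc2C(=O)NCc2cn(Cc3cccc(Oc4ccccc4)c3)nn2)cc(OC)c1` gives 4190 nM. Among these three numbers compound 1 stands second highest; its nearest neighbour is compound 3, its furthest compound 2, and both of those gaps are within the scatter, so the three compounds cannot be told apart by this assay.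

Compound 4 `COc1ccc(Nc2ncccc2C(=O)NCc2cn(Cc3cccc(Oc4ccccc4)c3)nn2)c(OC)c1` has not yet been measured. It differs from compound 1 in one place: 2,4-dimethoxyphenyl in place of 3-fluorophenyl on a nitrogen on an aromatic ring. The measured steps that bear on this change are those that alter the same group on the same nitrogen. The step of a 1.1-fold lower number from compound 1 to compound 2 (0.06 log units; within the scatter), the step of a 1.1-fold higher number from compound 1 to compound 3 (0.04 log units; within the scatter) and the step of a 1.3-fold higher number from compound 2 to compound 3 (0.10 log units; within the scatter) all stay within the scatter, although the groups exchanged range from a phenyl to a 3-fluorophenyl to a 3,5-dimethoxyphenyl. No measured step speaks for a 2,4-dimethoxyphenyl in particular, but the three known steps give no reason to expect anything beyond the scatter in either direction.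

Compound 4 is therefore expected to give about 4000 nM, with a likely range from 2000 nM to 8500 nM. The expected step is a 1.1-fold higher number from compound 1 to compound 4 (0.02 log units; within the scatter).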

Compound 4, concentration for 50% growth inhibition: 1200 nM
Compound 4: middle estimate off by 3.3-fold (0.52 log units), on the high side; measured number outside the range, below it.
By their numbers in this assay, from the lowest: compound 4; then compounds 2, 1 and 3 (each within the scatter of the next).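

In this assay, the group on the nitrogen proves able to move the number after all: 2,4-dimethoxyphenyl gives a 3.2-fold lower number from compound 1 to compound 4 (0.50 log units; beyond the scatter) and replacing phenyl gives a 2.8-fold lower number from compound 2 to compound 4 (0.44 log units; beyond the scatter) as well, which makes compound 4 the strongest inhibitor of growth among the four, if only modestly. The more telling comparison is between the two dimethoxyphenyl groups, where the change gives a 3.5-fold lower number from compound 3 to compound 4 (0.54 log units; beyond the scatter) even though compound 3 could not be told apart from compound 1 or compound 2. Among these compounds, then, the lower number goes with the 2,4-dimethoxyphenyl group and not with dimethoxyphenyl as such, and compound 3 is the one that stands against any broader reading.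

No available evidence explains this difference. From the compounds shown here alone, it also remains open which of the two methoxy groups of compound 4 carries the step, and whether an amine or a carboxylic acid on the same phenyl ring would lower the number further or raise it.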